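The source may hold more compounds than are shown below. What is called first, only, known or untested is meant among the compounds shown, and "the series" means these compounds.

Compound 3 `COc1cc2c(Oc3ccc(NC(=O)c4cn(-c5ccccc5C)nn4)cc3F)ccnc2cc1OCCCN1CCCCC1` gives the highest number of the three measured in a functional assay on A549 cells (Homo sapiens) for cytotoxicity, read by MTT assay, with a stated time of 72 h (a higher number here means a weaker inhibitor, a lower number a stronger inhibitor), namely 3230 nM. Compound 1 `COc1cc2c(Oc3ccc(NC(=O)c4cn(-c5ccccc5C)nn4)cc3F)ccnc2cc1OCCCN1CCCC1` gives 900 nM in this assay, and compound 2 `COc1cc2c(Oc3ccc(NC(=O)c4cn(-c5ccccc5)nn4)cc3F)ccnc2cc1OCCCN1CCCCC1` gives 130 nM. Compound 4 `COc1cc2c(Oc3ccc(NC(=O)c4cn(-c5ccccc5F)nn4)cc3F)ccnc2cc1OCCCN1CCCCC1` differs from compound 3 by fluoro in place of methyl on an aromatic carbon. Of the two measured steps, a 3.6-fold higher number from compound 1 to compound 3 (0.55 log units; beyond the scatter) concerns the exchange of pyrrolidin-1-yl for piperidin-1-yl on the chain and does not bear on the present change. The step that does is a 25-fold higher number from compound 2 to compound 3 (1.40 log units; beyond the scatter); read in reverse, taking the methyl off this aromatic carbon brings a large fall in number. Going by the values given here, compound 4 takes that same methyl off but sets a fluoro in its place, and no measured pair shows fluoro against hydrogen at this carbon, so a full return to the number of compound 2 is not assured. A large step down is therefore expected, a 9.2-fold lower number from compound 3 to compound 4 (0.97 log units; beyond the scatter). The estimate for compound 4 in this assay is 350 nM, with a range from 120 nM to 1000 nM.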

Compound 4, half-maximal inhibitory concentration: 2770 nM
Beside the measured number, compound 4's estimate is 7.9-fold (0.90 log units) below it; the measured number lies above the stated range.
By their numbers in this assay, from the lowest: compound 2; then compound 1; then compounds 4 and 3 (each within the scatter of the next).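

In this assay, the two groups at this aromatic carbon cannot be told apart: a 1.2-fold lower number from compound 3 to compound 4 (0.07 log units; within the scatter). Fluoro in place of hydrogen is a large step of the same direction as methyl in place of hydrogen, a 21-fold higher number from compound 2 to compound 4 (1.33 log units; beyond the scatter) against a 25-fold higher number from compound 2 to compound 3 (1.40 log units; beyond the scatter), so in these compounds the large rise in number is tied to neither methyl alone nor a carbon substituent alone, but is seen with both groups. Nothing at hand gives a reason for this result.

From the compounds shown here alone, whether a chloro or methoxy group on this carbon gives the same high number remains open. Also open, going by these compounds, is whether pyrrolidin-1-yl in place of piperidin-1-yl on the chain shifts the number with 2-fluorophenyl as it does with 2-methylphenyl.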